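A few compounds are considered here, and "the series" means these few. Any claim that something is new, unique, unknown or untested is made for them only; others in the source may bear on it.

Compound 1 `Cn1c(-c2ccc(NC(=O)CCl)cc2)nc(-c2ccccc2)c1-c1ccccc1` stands second highest of the three numbers in a functional assay on HT-29 cells (Homo sapiens) for cytotoxicity, read by MTT assay, with a stated time of 24 h, tested at 80 ug/mL (on this read-out lower numbers stand for a weaker effect and higher numbers for a stronger effect at the one concentration tested), giving 76.1%. Compound 2 `Cn1c(-c2ccc(NC(=O)CSc3nc4ccccc4o3)cc2)nc(-c2ccccc2)c1-c1ccccc1` gives 81.5%, and the step between them is a number 5.4 percentage points higher from compound 1 to compound 2 (within the scatter). Compound 3 `CN1CCN(CC(=O)Nc2ccc(-c3nc(-c4ccccc4)c(-c4ccccc4)n3C)cc2)CC1` gives 53.1%, with a number 23 percentage points lower from compound 1 to compound 3 (beyond the scatter) and a number 28.4 percentage points lower from compound 2 to compound 3 (beyond the scatter). Compound 4 `CCN1CCN(CC(=O)Nc2ccc(-c3nc(-c4ccccc4)c(-c4ccccc4)n3C)cc2)CC1` differs from compound 1 in one place: 4-ethylpiperazin-1-yl in place of chloro on a saturated chain carbon bound to a carbonyl carbon. Within the data shown here, the steps that bear on this are the two into compound 3, both modest losses beyond the scatter where 4-methylpiperazin-1-yl enters at the same place, so a downward step of similar size is expected here, a number 24.1 percentage points lower from compound 1 to compound 4 (beyond the scatter). Compound 4 is therefore estimated at 52% in this assay, with a range from 38% to 66%.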

Compound 4, a percentage reported as activity, at one concentration (the size of the read-out at that concentration, not a potency): 51.2%
For compound 4 the middle estimate is 0.8 percentage points above the measured one, within the range that was stated.
By their numbers in this assay, from the lowest: compounds 4 and 3 (each within the scatter of the next); then compounds 1 and 2 (each within the scatter of the next).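

In this assay, methyl in place of hydrogen on a saturated chain carbon bound to an amine nitrogen in a ring gives a number 1.9 percentage points lower from compound 3 to compound 4 (within the scatter), so 4-ethylpiperazin-1-yl and 4-methylpiperazin-1-yl cannot be told apart at this position. The loss beyond the scatter therefore holds for both groups: 4-ethylpiperazin-1-yl gives a number 24.9 percentage points lower from compound 1 to compound 4 (beyond the scatter) in place of chloro and a number 30.3 percentage points lower from compound 2 to compound 4 (beyond the scatter) in place of (1,3-benzoxazol-2-yl)sulfanyl. No available measurement explains these steps. Still open, as far as these compounds go, is how morpholin-4-yl, unsubstituted piperazin-1-yl or 4-propylpiperazin-1-yl would read at this place.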